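The source may hold more compounds than are shown below. What is called first, only, known or untested is meant among the compounds shown, and "the series" means these compounds.

Working notes on the series. Of the compounds shown here, three built on the shared core have been measured: compound 1 `Fc1ccc(Oc2cncc(C3=CC4CNCC(C3)C4)c2)cc1`, compound 2 `CN1CC2C=C(c3cncc(C#N)c3)CC(C2)C1` and compound 3 `COc1cncc(C2=CC3CC(C2)CN(C)C3)c1`. In an in vitro assay on SH-EP1 cells for displacement of a labelled ligand from Neuronal acetylcholine receptor; alpha4/beta2 (Homo sapiens) (on this read-out lower numbers stand for stronger inhibition and higher numbers for weaker inhibition), compound 1 gives 0.6 nM. In this assay compound 3 gives 0.6 nM. In this assay compound 2 gives 24 nM. Compound 1 and compound 3 sit level at the digits shown, together the lowest of the three numbers. Among the compounds with values here, compound 2 stands apart from both, and the only single-point step recorded so far is a 40-fold lower number from compound 2 to compound 3 (1.60 log units; beyond the scatter), a methoxy in place of a cyano on an aromatic carbon.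

Compound 4 `C1=C(c2cncc(Oc3ccccc3)c2)CC2CNCC1C2` is the next candidate, differing from compound 1 in one place: hydrogen in place of fluoro on an aromatic carbon. Within the data shown here, no measured step speaks to this change. Among the measured compounds shown here, the one known step concerns a different group on a different ring and was large, but it gives no guidance on removing a fluoro from the phenyl ether. Compound 1 and compound 3 show that the phenoxy and the methoxy partners both reach the low end of the range, so the expectation for compound 4 is a step of a 1.2-fold higher number from compound 1 to compound 4 (0.07 log units; within the scatter) in this assay, within the scatter. Compound 4 is therefore estimated at 0.7 nM, with a range from 0.3 nM to 1.8 nM.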

Compound 4, inhibition constant: 0.7 nM
Estimate against measurement, compound 4: no gap at the digits printed; low and high end bracket the measured number.
By their numbers in this assay, from the lowest: compounds 1, 3 and 4 (each within the scatter of the next); then compound 2.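

In this assay the change 4-fluorophenyl to phenyl gives a 1.2-fold higher number from compound 1 to compound 4 (0.07 log units; within the scatter) and so reads as no real change: at this place, para to a large group, hydrogen stands in for fluoro within the scatter. Within the data shown here, this is the first single-point step recorded on the phenyl ring, and it contrasts with the large step on the other aromatic ring, a 40-fold lower number from compound 2 to compound 3 (1.60 log units; beyond the scatter) in the same assay. Nothing at hand accounts for this outcome.

The compounds shown carry only hydrogen and fluoro at this place, so it remains open whether a chloro, an amine or a carboxylic acid there would also leave the number unchanged. Also open, on these data alone, is whether the same exchange reads the same with a methyl on the nitrogen of the shared core.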